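Swapping bromine for iodine on a compound at the limit

The compounds below may be only part of what the source reports. "The series", "measured", "known", "first", "only" and "open" are said of these compounds alone.

In a functional assay on HL-60 cells (Homo sapiens), read by calcium flux (on this read-out lower numbers stand for an effect already at smaller amounts and higher numbers for an effect only at larger amounts of compound), compound 1 `COc1cc(Cc2cc(C)nn(CC(=O)Nc3ccc(Br)cc3)c2=O)cc(OC)c1` gives > 50000 nM, which is a limit of the assay rather than a measured number. Compound 2 `Cc1cc(Cc2cccs2)c(=O)n(CC(=O)Nc2ccc(Br)cc2)n1` likewise gives > 50000 nM in this assay, again only a limit. The step that the two limits leave unreadable from compound 1 to compound 2 therefore cannot be sized, since both values sit at the limit of > 50000 nM in this assay, at which 2 of the 2 values shown sit. Compound 3 `COc1cc(Cc2cc(C)nn(CC(=O)Nc3ccc(I)cc3)c2=O)cc(OC)c1` differs from compound 1 by iodo in place of bromo on an aromatic carbon, para to a large group. Going by the values given here, no measured step touches this halogen, and the single measured step is unreadable, so the numbers give no basis to expect a move beyond the scatter in either direction. Compound 3 is estimated at 60000 nM, within a range of 20000 nM to 200000 nM, and will most probably be reported again only as a limit. The step that the limit leaves unreadable from compound 1 to compound 3 is expected to be essentially none.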

Compound 3, half-maximal effective concentration: > 50000 nM
Compound 3 gave a limit, no number (the forecaster's own chance of this, stated with the estimate: 85%); the middle value does not contradict the limit.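

Compound 1 and compound 3 both stop at a limit of the assay in this assay, so no step can be read for iodo in place of bromo: the limit of > 50000 nM in this assay, at which 3 of the 3 values shown sit.

The compounds shown leave open whether any change to the shared core would give a real number in this assay.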